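The compounds below may be only part of what the source reports. "The series", "measured", "known", "first", "only" and "open" are said of these compounds alone.

Measured compounds:
Compound 1, `CC1=CC[C@H](C(C)(C)NC(=S)N/N=C/c2ccc(O)cc2)CC1`, in a functional assay on OVCAR-3 cells (Homo sapiens) for inhibition, read by sulforhodamine B assay, with a stated time of 48 h (a lower number here means a stronger inhibitor of growth, a higher number a weaker inhibitor of growth), reaches only the limit > 100000 nM.
Compound 2, `CC1=CC[C@H](C(C)(C)NC(=S)N/N=C/c2ccc(N(C)C)cc2)CC1`, in this assay likewise reaches only the limit > 100000 nM.

Compound 2 therefore stands at no number at all in this assay, but at the assay's limit, the same place as compound 1; the step that the two limits leave unreadable from compound 1 to compound 2 cannot be read, and all that the data show is the limit of > 100000 nM in this assay, at which 2 of the 2 values shown sit. Compound 3, `CC1=CC[C@H](C(C)(C)NC(=S)N/N=C/c2ccc(Cl)cc2)CC1`, differs from compound 2 by chloro in place of dimethylamino on an aromatic carbon. Among the measured compounds shown here, no measured step bears on this change, since the only step between measured compounds is unreadable. With nothing to anchor a direction, compound 3 is expected to remain near the limit, so the estimated step of a number no higher from compound 2 to compound 3 (the limit leaves the size open) is one of no readable size. Compound 3 is therefore estimated at 100000 nM in this assay, within 20000 nM to 300000 nM.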

Compound 3, concentration for total growth inhibition: 26400 nM
Compound 3: the middle estimate sits 3.8-fold (0.58 log units) above what was measured, and the stated range covers the measured number.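

In this assay, among the compounds shown here, compound 3 is the first of the series to give a number rather than a limit, which shows that the group on this aromatic carbon can shift growth inhibition on the shared core. Chloro in place of dimethylamino gives an at least 3.7-fold lower number from compound 2 to compound 3 (0.57 log units; beyond the scatter), and chloro in place of hydroxy at the same place gives an at least 3.7-fold lower number from compound 1 to compound 3 (0.57 log units; beyond the scatter). Both steps are lower bounds rather than sizes, since each starts from a compound that reaches only a limit: the limit of > 100000 nM in this assay, at which 2 of the 3 values shown sit.

The compounds shown leave open whether this shift is particular to chloro or would also appear with fluoro, bromo, methyl or trifluoromethyl at this place. Also open, as far as these compounds go, is whether a carboxylic acid or a primary amine there would stay at the limit, as hydroxy and dimethylamino do.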